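This account rests on a few compounds, and the source may have more. Where it says the series, first, only, none or still open, it means among the compounds named here.

Measured compounds:
Compound 1 `Cc1cccc(NC(=O)CN2CCC(c3ccccc3)CC2)c1` gives 15.4 nM.
Compound 2 `Cc1cccc(NC(=O)CCN2CCN(c3ncccn3)CC2)c1` gives 568 nM.
Compound 3 `Cc1ccc(C2CCN(CC(=O)Nc3cccc(C)c3)CC2)cc1` gives "not active" (no number reported), with no number given.

In a functional assay on cells for agonist activity at D(4) dopamine receptor (Homo sapiens), read by TR-FRET and cAMP accumulation, with a stated time of 30 min (a higher number here means that more compound is needed for the effect, a lower number that less compound is needed), compound 2 gives 568 nM, the higher of the two numbers reported; compound 1 gives 15.4 nM, a gap well beyond the usual scatter, while compound 3 returned no number at all. Compound 4 `Cc1cccc(NC(=O)CCN2CCN(c3ccccn3)CC2)c1` differs from compound 2 in one place: pyridin-2-yl in place of pyrimidin-2-yl on an amine nitrogen in a ring. For the measured compounds named here, no step between measured compounds isolates this change, so the numbers at hand say nothing about its size. The writer expects a small step in this assay toward a lower number, possibly not beyond the scatter, since the rest of the structure of compound 2 is kept unchanged. For compound 4 the estimate in this assay is 250 nM, with a range from 60 nM to 1000 nM. This corresponds to an expected step of a 2.3-fold lower number from compound 2 to compound 4 (0.36 log units; beyond the scatter), which is to be taken as a guess until the measurement is in hand.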

Compound 4, half-maximal effective concentration: 612 nM
Estimate against measurement, compound 4: 2.4-fold (0.39 log units) below, within the range that was stated.
By their numbers in this assay, from the lowest: compound 1; then compounds 2 and 4 (each within the scatter of the next).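

In this assay, the exchange of pyrimidin-2-yl for pyridin-2-yl on the amine nitrogen in the ring gives a 1.1-fold higher number from compound 2 to compound 4 (0.03 log units; within the scatter), so the two compounds cannot be told apart. The earlier compounds shown here offered no step at this position, and this first one shows that the exchange, which takes the group from 2 hetero atoms to 1 and from 2 hydrogen-bond acceptors to 1, leaves the reading within the scatter at this point of the structure. Nothing at hand bears on the reason for this result.

The compounds shown leave open whether a phenyl group, with no ring nitrogen, or a pyrazin-2-yl group at the same place would also stay within the scatter of compound 2. They also leave open whether the same exchange would read alike on a shorter chain between the amide and the ring.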